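The compounds below may be only part of what the source reports. "The series", "measured", "known", "first", "only" and "open" are said of these compounds alone.

For the measured compounds named here, compound 3 `CC(C)=CCC/C(C)=C/CC1Cc2c(OCCCNS(=O)(=O)c3ccc(Cl)cc3)cc(=O)n(CCCO)c2CC1(C)C` gives 14.5% in a functional assay on PANC-1 cells (Homo sapiens) for inhibition, read by MTT assay, with a stated time of 24 h, tested at 10 uM (on this read-out lower numbers stand for less inhibition and higher numbers for more inhibition at the one concentration tested (going by the name of the read-out)), the lowest of the three numbers so far; compound 1 `CC(C)=CCC1Cc2c(OCCCNS(=O)(=O)c3ccc(Br)cc3)cc(=O)n(CCCO)c2CC1(C)C` gives 19.5%, within the scatter of it, while compound 2 `CCOc1cc(=O)n(CCCO)c2c1CC(C/C=C(\C)CCC=C(C)C)C(C)(C)C2` gives 67.8%, well beyond. Going by the values given here, the single recorded step, a number 53.3 percentage points lower from compound 2 to compound 3 (beyond the scatter), concerns the sulfonamide-bearing chain rather than the halogen. Compound 4 `CC(C)=CCC/C(C)=C/CC1Cc2c(OCCCNS(=O)(=O)c3ccc(Br)cc3)cc(=O)n(CCCO)c2CC1(C)C` differs from compound 3 by bromo in place of chloro on an aromatic carbon. Among the compounds with values here, no measured pair isolates this exchange: compounds 1 and 3 carry the two halogens but also differ in their side chains, and their values lie within the scatter of each other. Compound 4 is therefore expected to show no step beyond the scatter, a number 2.5 percentage points higher from compound 3 to compound 4 (within the scatter). The inhibition of compound 4 is estimated at 17%, between 5% and 30%.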

Compound 4, a percentage reported as inhibition, at one concentration (the size of the read-out at that concentration, not a potency): 15.2%
Estimate against measurement, compound 4: 1.8 percentage points above; low and high end bracket the measured number.
By their numbers in this assay, from the lowest: compounds 3, 4 and 1 (each within the scatter of the next); then compound 2.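

In this assay the exchange of chloro for bromo, taken on its own, gives a number 0.7 percentage points higher from compound 3 to compound 4 (within the scatter) and so shows no readable effect of the halogen on this aromatic carbon para to a large group. The large gap seen with chloro recurs with bromo, as (((4-bromophenyl)sulfonyl)amino)methyl in place of hydrogen gives a number 52.6 percentage points lower from compound 2 to compound 4 (beyond the scatter) and the shorter side chain of compound 1 matters little, with a number 4.3 percentage points lower from compound 1 to compound 4 (within the scatter) for 3-methylbut-2-en-1-yl in place of hydrogen. Nothing on hand explains these numbers.

From the compounds shown here alone, whether an amine or a carboxylic acid on this aromatic carbon would move the number stays open. So does whether the low numbers follow the whole sulfonylamino chain or only its halophenyl end.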